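The compounds below may be only part of what the source reports. "The series", "measured", "known", "first", "only" and "open" are said of these compounds alone.

Of the compounds shown here, two of the shared core have been measured in a functional assay, read by spectrophotometry, with a stated time of 2 h; on this read-out higher numbers stand for weaker inhibition and lower numbers for stronger inhibition. Compound 1 `CCOC(=O)C1=C(C)NC(=O)NC1c1ccc(O)cc1` gives 2.71 ug/mL, while compound 2 `COC(=O)C1=C(C)NC(=O)NC1c1ccccc1` gives 28.4 ug/mL, the highest of the two numbers, and these two compounds differ in more than one place, so no single step can be read from them. Compound 3 `COC(=O)C1=C(C)NC(=O)NC1c1ccc([N+](=O)[O-])cc1` differs from compound 2 by one change: nitro in place of hydrogen on an aromatic carbon. For the measured compounds named here, with no step between measured compounds available, the expected step of a 1.3-fold lower number from compound 2 to compound 3 (0.11 log units; within the scatter) is small and likely within the scatter. Compound 3 is estimated at 22 ug/mL, within the range 7 ug/mL to 70 ug/mL.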

Compound 3, half-maximal inhibitory concentration: 27.8 ug/mL
Compound 3: the middle estimate sits 1.3-fold (0.10 log units) below what was measured, within the range that was stated.
By their numbers in this assay, from the lowest: compound 1; then compounds 3 and 2 (each within the scatter of the next).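

In this assay, nitro in place of hydrogen on an aromatic carbon, on a six-membered aromatic ring of carbon only, gives a 1.0-fold lower number from compound 2 to compound 3 (0.01 log units; within the scatter). For the compounds shown here, this is the first step that can be read, and it shows that adding these 3 heavy atoms at this place leaves the number within the scatter. No available measurement bears on the reason for this result.

Whether the hydroxyl or the ethyl ester of compound 1 accounts for its separation from compound 2 remains unresolved, as those compounds differ in more than one place. As far as these compounds go, the outcome with an amine or a carboxylic acid on this aromatic carbon also remains open.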